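Cyclohexylmethyl to Isopropyl on a Vinylsulfonamide Scaffold

The compounds below may be only part of what the source reports. "The series", "measured", "known", "first", "only" and "open" are said of these compounds alone.

Compound 1 `C=CC(=O)NC/C=C/c1cc(OC)cc(O)c1C(=O)OC(C)C`: in a functional assay on MV4-11 cells (Homo sapiens) for antiproliferative activity, read by luminescence, with a stated time of 72 h (on this read-out lower numbers stand for stronger inhibition and higher numbers for weaker inhibition), compound 1 gives > 10000 nM, which is a limit of the assay rather than a number.
Compound 2 `COc1cc(O)c(C(=O)OC(C)C)c(/C=C/CNC(C)=O)c1`: in this assay compound 2 gives > 10000 nM, again a limit of the assay.
Compound 3 `C=CS(=O)(=O)NC/C=C/c1cc(OC)cc(O)c1C(=O)OCC1CCCCC1`: in this assay compound 3 gives 5860 nM.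

Compound 3 is thus the only one of the three measured compounds with an actual number; the other two sit at the limit of > 10000 nM in this assay, at which 2 of the 3 values shown sit. Among the compounds with values here, the single step measured between compounds, a step that the two limits leave unreadable from compound 1 to compound 2, cannot be read, since both of its ends are limits.

Compound 4 `C=CS(=O)(=O)NC/C=C/c1cc(OC)cc(O)c1C(=O)OC(C)C` differs from compound 3 by isopropyl in place of cyclohexylmethyl on an oxygen next to a carbonyl group. Within the data shown here, no measured step bears on this change directly. What the data do show is that compound 1, which carries the isopropyl group that enters here, returned only a limit, whereas compound 3 with the cyclohexylmethyl group returned a number. On that footing the writer expects compound 4 to be weaker than compound 3, with a step estimated at a 2.0-fold higher number from compound 3 to compound 4 (0.31 log units; beyond the scatter). Compound 4 is therefore estimated at 12000 nM, expected to lie between 4000 nM and 40000 nM, with a real chance that the assay reports only a limit.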

Compound 4, half-maximal inhibitory concentration: 4660 nM
Compound 4: middle estimate off by 2.6-fold (0.41 log units), on the high side; the range from low to high includes it.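

At this position, on an oxygen next to a carbonyl group, cyclohexylmethyl and isopropyl cannot be told apart in this assay, with a 1.3-fold lower number from compound 3 to compound 4 (0.10 log units; within the scatter), so the six-membered ring is not required for the activity seen here. With isopropyl held constant, the group on the amine nitrogen now appears as the change that counts, since vinylsulfonyl in place of acetyl gives an at least 2.1-fold lower number from compound 2 to compound 4 (0.33 log units; beyond the scatter), and vinylsulfonyl in place of vinylcarbonyl gives an at least 2.1-fold lower number from compound 1 to compound 4 (0.33 log units; beyond the scatter). Both of these steps start from a limit of the assay and not from a number: the limit of > 10000 nM in this assay, at which 2 of the 4 values shown sit.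

The compounds shown leave open whether the vinyl part of the vinylsulfonyl group matters, which a methylsulfonyl group on the same nitrogen would test. They also leave open how a carboxylic acid would read in place of the ester.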